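This account rests on a few compounds, and the source may have more. Where it says the series, first, only, none or still open, it means among the compounds named here.

Measured compounds in an assay for inhibition of Polyunsaturated fatty acid lipoxygenase ALOX12 (Homo sapiens), read by spectrophotometry; on this read-out lower numbers stand for stronger inhibition and higher numbers for weaker inhibition:
- compound 1 `CC(=O)NC(c1ccco1)c1cc(F)c2cccnc2c1O` gives 5000 nM
- compound 2 `CCC(=O)NC(C)c1cc(Cl)c2cccnc2c1O` gives only a limit, > 50000 nM
- compound 3 `CC(=O)NC(c1ccco1)c1cc(Cl)c2ccc(N3CCCCC3)nc2c1O` gives only a limit, > 75000 nM

Compound 2 stands at a limit of this assay, not at a number (the limit of > 50000 nM in this assay, at which 1 of the 3 values shown sits). Compound 3 likewise sits at a limit (the limit of > 75000 nM in this assay, at which 1 of the 3 values shown sits). Only compound 1 returns a number. Within the data shown here, no step between measured compounds that differ in one place is available, so nothing on the effect of a single change is known from the series itself.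

Compound 4 `CCC(=O)NC(c1ccc(F)cc1)c1cc(Cl)c2cccnc2c1O` differs from compound 2 by 4-fluorophenyl in place of methyl on a saturated chain carbon bound to an amide-type nitrogen and an aromatic carbon. Among the measured compounds shown here, compound 1 carries an aromatic ring at the same carbon and is the one measured compound with a number, so an aryl group there is expected to bring compound 4 back from the limit into the measurable range. The expected step from compound 2 to compound 4 is an at least 5.0-fold lower number from compound 2 to compound 4 (0.69 log units; beyond the scatter), a gain beyond the scatter. Compound 4 is estimated at 10000 nM, within 3000 nM to 40000 nM.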

Compound 4, half-maximal inhibitory concentration: > 50000 nM
Compound 4 gave a limit, no number; the forecaster's own chance of this, stated with the estimate: 25%; at least 5.0-fold (0.69 log units) between middle value and limit.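

Compound 2 and compound 4 both stand at a limit, not a number, in this assay, so no step can be read between them: the limit of > 50000 nM in this assay, at which 2 of the 4 values shown sit.

The compounds shown leave open whether 4-fluorophenyl in place of methyl changes inhibition at all.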